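Cytotoxicity notes on an amide-to-urea change in one series

The source may report more compounds than this note shows. Statements on the series, on what has been measured and on what is new or still open speak of the compounds shown alone.

Measured compounds:
compound 1 `CN(C)c1cc2[nH]c(C3CCCCC3)nc2cc1NC(=O)c1ccccc1`: > 100 ug/mL 
compound 2 `CCCN(CCC)c1cc2[nH]c(C3CCCCC3)nc2cc1NC(=O)c1ccccc1`: > 100 ug/mL 
compound 3 `O=C(Nc1cc2nc(C3CCCCC3)[nH]c2cc1N1CCCC1)c1ccccc1`: > 100 ug/mL 

In an ADME assay on Vero cells (Chlorocebus sabaeus) for cytotoxicity, read by resazurin assay, with a stated time of 3 days (a higher number here means a weaker inhibitor, a lower number a stronger inhibitor), compound 1 reaches only the limit of the assay, > 100 ug/mL, not a number. Compound 2 likewise gives a limit in this assay, > 100 ug/mL. Compound 3 gives a limit in this assay as well, > 100 ug/mL. All three values sit at the limit of > 100 ug/mL in this assay, at which 3 of the 3 values shown sit, so the steps a step that the two limits leave unreadable from compound 1 to compound 2, a step that the two limits leave unreadable from compound 1 to compound 3 and a step that the two limits leave unreadable from compound 2 to compound 3 cannot be read in size or direction; they show only that swapping the amine on the aromatic carbon left every compound at the limit.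

Compound 4 `CCCCNC(=O)Nc1cc2nc(C3CCCCC3)[nH]c2cc1N(C)C` differs from compound 1 by butylamino in place of phenyl on a carbonyl carbon. Going by the values given here, none of the measured steps touches the carbonyl side of the core, so nothing measured bears directly on this change, and the limits rule out reading any step at all. The expectation is simply that compound 4 stays at the limit in this assay, and the step that the limit leaves unreadable from compound 1 to compound 4 is expected to be unreadable for the same reason. Compound 4 is therefore estimated at 120 ug/mL, between 60 ug/mL and 250 ug/mL, most likely reported as a limit.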

Compound 4, half-maximal inhibitory concentration: > 100 ug/mL
Compound 4 was reported as a limit; the forecaster's own chance of this, stated with the estimate: 85%; the middle value is on the limit's open side.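

In this assay compound 4 gives > 100 ug/mL, a limit and not a number. No size or direction can be read for its step from compound 1, since both compounds stand at the same limit: the limit of > 100 ug/mL in this assay, at which 4 of the 4 values shown sit.

The compounds shown leave open where each true value lies, and whether butylamino in place of phenyl on a carbonyl carbon changes cytotoxicity at all.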